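Thiophen-3-yl in Place of Thiophen-2-yl on the Carbonyl

A few compounds are considered here, and "the series" means these few. Any claim that something is new, unique, unknown or untested is made for them only; others in the source may bear on it.

Compound 1 `COc1ccc(-c2cc3ccccc3nc2/C=C/C(=O)c2c(OC)cccc2OC)cc1`: 4520 nM
Compound 2 `COc1ccc(-c2cc3ccccc3nc2/C=C/C(=O)c2cccs2)cc1`: 1030 nM

Within the data shown here, in a functional assay on MCF7 cells (Homo sapiens) for antiproliferative activity, read by XTT assay, with a stated time of 72 h (on this read-out higher numbers stand for weaker inhibition and lower numbers for stronger inhibition), compound 2 holds the lower of the two numbers, and the only measured step, a 4.4-fold lower number from compound 1 to compound 2 (0.64 log units; beyond the scatter), lies beyond the scatter. Compound 3 `COc1ccc(-c2cc3ccccc3nc2/C=C/C(=O)c2ccsc2)cc1` differs from compound 2 in one place: thiophen-3-yl in place of thiophen-2-yl on a carbonyl carbon. Among the measured compounds shown here, no measured step concerns this change; the single known step was a different replacement on the same carbonyl carbon, so it gives no direction here. Compound 3 is therefore expected to give 1200 nM (range 500 nM to 3000 nM), an estimated step of a 1.2-fold higher number from compound 2 to compound 3 (0.07 log units; within the scatter) that is not expected to exceed the scatter.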

Compound 3, half-maximal inhibitory concentration: 6010 nM
Compound 3: the middle estimate sits 5.0-fold (0.70 log units) below what was measured; the measured number lies above the stated range.
By their numbers in this assay, from the lowest: compound 2; then compounds 1 and 3 (each within the scatter of the next).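

In this assay, where the thiophene ring is joined to the carbonyl carbon matters: with the same atoms, thiophen-3-yl in place of thiophen-2-yl gives a clear loss (a 5.8-fold higher number from compound 2 to compound 3 (0.77 log units; beyond the scatter)). The advantage over 2,6-dimethoxyphenyl therefore belongs to thiophen-2-yl and does not carry over to thiophen-3-yl (a 1.3-fold higher number from compound 1 to compound 3 (0.12 log units; within the scatter)). No evidence at hand accounts for this difference. From the compounds shown here alone, it remains open whether furan-2-yl or pyridin-2-yl on the same carbonyl carbon would match compound 2 or fall towards compound 3.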